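This account rests on a few compounds, and the source may have more. Where it says the series, first, only, none or still open, it means among the compounds named here.

Compounds measured in an ADME assay on Caco-2 cells (Homo sapiens) for permeability, in the apical to basolateral direction; a lower number here means that the compound crosses the layer more slowly, a higher number that the compound crosses the layer faster:

Compound 1, `Cn1cc(-c2nc3c(-c4ccc(CNC(=O)c5nc(C(C)(C)C)no5)c(F)c4)ccnc3[nH]2)cn1`: 11 10^-6 cm/s
Compound 2, `CC(C)(C)c1noc(C(=O)NCc2ccc(-c3ccnc4[nH]c(-c5cnn(C6CCOCC6)c5)nc34)cc2F)n1`: 0.8 10^-6 cm/s
Compound 3, `Cn1cc(-c2nc3c(-c4ccc5c(c4)CCCC5NC(=O)c4nc(C(C)(C)C)no4)ccnc3[nH]2)cn1`: 1 10^-6 cm/s

Compound 1 and compound 2 share one core and differ at a single place: oxan-4-yl in place of methyl on an aromatic nitrogen. In this assay this change gave a 14-fold lower number from compound 1 to compound 2 (1.14 log units; beyond the scatter), so compound 2 crosses the cell layer a good deal more slowly than compound 1.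

Compound 3 carries the same amide and the same pyrazole-bearing core as compound 1, but the part around the amide nitrogen is built differently; the difference between the two cores is not broken down here. In this assay compound 3 gives a number that is already far lower than that of compound 1, and close to that of compound 2.

Compound 4, `CC(C)(C)c1noc(C(=O)NC2CCCc3cc(-c4ccnc5[nH]c(-c6cnn(C7CCOCC7)c6)nc45)ccc32)n1`, is not yet measured in this assay. It stands to compound 3 exactly as compound 2 stands to compound 1: oxan-4-yl in place of methyl on an aromatic nitrogen. Both changes sit at the same place with the same surroundings, so this is the same change. Going by the values given here, the only measured instance of this change, in compound 1 to compound 2, is the large drop recorded above, and it is expected that the step from compound 3 to compound 4 in this assay will be of a similar size, an 8.3-fold lower number from compound 3 to compound 4 (0.92 log units; beyond the scatter), because of a 14-fold lower number from compound 1 to compound 2 (1.14 log units; beyond the scatter). On that basis compound 4 is estimated at 0.12 10^-6 cm/s in this assay, expected to lie between 0.03 10^-6 cm/s and 0.5 10^-6 cm/s; a value this low may come back from the assay only as a limit.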

Compound 4, apparent permeability: 0.4 10^-6 cm/s
Beside the measured number, compound 4's estimate is 3.3-fold (0.52 log units) below it, and the stated range covers the measured number.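

In this assay, oxan-4-yl in place of methyl on the aromatic nitrogen of the pyrazole again lowers the number, giving a 2.5-fold lower number from compound 3 to compound 4 (0.40 log units; beyond the scatter), so the direction of the change holds on both cores shown and the step lies beyond the scatter on each. Going by these compounds alone, the size of the step does not carry over, and the two instances differ by more than the scatter allows: the same change on two cores in this assay, a 14-fold lower number (1.14 log units; beyond the scatter) from compound 1 to compound 2 and a 2.5-fold lower number (0.40 log units; beyond the scatter) from compound 3 to compound 4, 5.5-fold (0.74 log units) apart, beyond the scatter of two such steps With only two cores, this shows that the change can be expected to lower the number as far as these compounds go, but it gives no reliable size for a further core and does not show what sets the size on either one.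

The compounds shown carry only methyl and oxan-4-yl on that nitrogen, so it remains open how a smaller group such as ethyl, or a ring bearing an amine such as piperidin-4-yl, would behave on either core. Also open, from the compounds shown here alone, is which part of the difference around the amide nitrogen goes with the gap between the two steps, and whether the gap would persist with another group in place of the tert-butyl.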